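This account rests on a few compounds, and the source may have more. Where it says the series, first, only, none or still open, it means among the compounds named here.

Working notes on the series in a functional assay on Ehrlich cells (Mus musculus) for cytotoxicity, read by trypan blue exclusion, with a stated time of 24 h, tested at 50 uM; on this read-out lower numbers stand for a weaker effect and higher numbers for a stronger effect at the one concentration tested.

Three compounds have numbers here. Compound 1 `COc1ccc(/C=C2\CCCC3C2=NN(C2=NC(=O)/C(=C/c4ccc(OC)c(OC)c4)S2)C3c2ccc(OC)cc2)cc1` gives 40% in this assay. Compound 2 `N#Cc1c(N)nc2c(c1-c1ccc(O)cc1)CCC/C2=C\c1ccc(O)cc1` gives 43.4%, a number close enough to that of compound 1 to lie within the usual scatter, so no order between the two can be read. Compound 3 `COc1ccc(/C=C/C2=NN(c3nc(-c4ccccc4)cs3)C(c3ccc(OC)cc3)C2)cc1` gives 61.6%, and here the gap to compound 1 lies beyond the scatter. Compound 1 thus stands lowest of the three numbers, though only compound 3 is separated from it beyond the scatter.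

Compound 4 `COc1ccc(/C=C2\CCCC3C2=NN(C2=NC(=O)/C(=C/c4ccc(Cl)cc4)S2)C3c2ccc(OC)cc2)cc1` has not been measured. It differs from compound 1 in one place: 4-chlorophenyl in place of 3,4-dimethoxyphenyl on a double-bonded chain carbon bound to a double-bonded ring carbon. Going by the values given here, no measured pair differs in only one place, so no step of this kind can be drawn on. The change is limited to the 4-chlorophenyl entering for the 3,4-dimethoxyphenyl on a double-bonded chain carbon bound to a double-bonded ring carbon, and the rest of the structure is shared with compound 1. The expectation for compound 4 is therefore a step of a number 5 percentage points higher from compound 1 to compound 4 (within the scatter) that stays within the scatter, with no clear direction. Compound 4 is estimated at 45%, within 30% to 62%.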

Compound 4, a percentage reported as activity, at one concentration (the size of the read-out at that concentration, not a potency) in the Ehrlich assay: 46%
The estimate for compound 4 lay 1 percentage points below the measured number, within the range that was stated.
By their numbers in the Ehrlich assay, from the lowest: compounds 1, 2 and 4 (each within the scatter of the next); then compound 3.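

Going by these compounds alone, at the place on a double-bonded chain carbon bound to a double-bonded ring carbon, 4-chlorophenyl in place of 3,4-dimethoxyphenyl gives the first single-place step: in the Ehrlich assay this is a number 6 percentage points higher from compound 1 to compound 4 (within the scatter) and no order can be read between the two compounds. In a physicochemical assay for inhibition, read by colorimetric assay, tested at 1 mg/mL (on this read-out lower numbers stand for less inhibition and higher numbers for more inhibition at the one concentration tested (going by the name of the read-out)), compound 1 gives 19.1% and compound 4 gives 25.7%, which is a number 6.6 percentage points higher from compound 1 to compound 4 (within the scatter) and so again allows no order, even with one aromatic ring kept at this place and its substituents exchanged. No supporting measurement bears on this result.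

As far as these compounds go, whether an amine or a carboxylic acid on the ring at this place would carry either read-out beyond the scatter stays open. So does the outcome of replacing the phenyl ring itself with a longer chain.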